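The source may report more compounds than this note shows. Statements on the series, on what has been measured and on what is new or still open speak of the compounds shown alone.

In a functional assay on MGC-803 cells (Homo sapiens) for antiproliferative activity, read by CellTiter-Glo, with a stated time of 72 h (on this read-out higher numbers stand for weaker inhibition and lower numbers for stronger inhibition), compound 1 (`O=C(NO)c1ccc(/C=C/c2ccnc(-c3ccccc3O)c2)cc1`) gives 1420 nM, compound 2 (`COc1ccccc1-c1cc(/C=C/c2ccc(C(=O)NO)cc2)ccn1`) gives 6350 nM and compound 3 (`O=C(NO)c1ccc(/C=C/c2ccnc(-c3cccc(O)c3)c2)cc1`) gives 2100 nM. Compound 3 cannot be separated from compound 1, with a 1.5-fold higher number from compound 1 to compound 3 (0.17 log units; within the scatter), but it stands clear of the highest number, with a 3.0-fold lower number from compound 2 to compound 3 (0.48 log units; beyond the scatter). Compound 4 (`O=C(NO)c1ccc(/C=C/c2ccnc(-c3ccc(F)cc3)c2)cc1`) carries 4-fluorophenyl in place of 3-hydroxyphenyl on an aromatic carbon. Going by the values given here, no fluorinated compound has been measured yet. The nearest evidence is the modest loss when methyl replaces hydrogen on the oxygen, a 4.5-fold higher number from compound 1 to compound 2 (0.65 log units; beyond the scatter). A modest rise in this assay is therefore expected, though a step within the scatter remains possible. The estimated step is a 1.4-fold higher number from compound 3 to compound 4 (0.15 log units; within the scatter). For compound 4 the expected value is 3000 nM, with an estimated range of 1200 nM to 7500 nM.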

Compound 4, half-maximal inhibitory concentration: > 10000 nM
Compound 4 ended at the assay's limit (the forecaster's own chance of this, stated with the estimate: 3%); at least 3.3-fold (0.52 log units) between middle value and limit.
By their numbers in this assay, from the lowest: compounds 1 and 3 (each within the scatter of the next); then compound 2. At a limit, above all of these: compound 4.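

In this assay compound 4 stands at a limit of the read-out, > 10000 nM, so its steps are floors only: the limit of > 10000 nM in this assay, at which 1 of the 4 values shown sits. On the aromatic carbon next to the ring nitrogen, 4-fluorophenyl gives an at least 4.7-fold higher number from compound 3 to compound 4 (0.67 log units; beyond the scatter) and an at least 7.0-fold higher number from compound 1 to compound 4 (0.84 log units; beyond the scatter), a clear loss against both hydroxyphenyl groups. The floor of an at least 1.5-fold higher number from compound 2 to compound 4 (0.19 log units; that floor lies within the scatter) does not separate compound 4 from compound 2, and these two compounds, which have no hydroxyl on this ring, carry the highest numbers.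

Compound 4 changes both the substituent and its place on the ring, so the two effects stay unseparated. Going by these compounds, how plain phenyl or an aminophenyl would behave here stays open.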